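A Methyl Added to a Growth-Inhibiting Compound

The compounds below may be only part of what the source reports. "The series", "measured", "known", "first", "only" and "open" are said of these compounds alone.

Compound 1 `N/C(=N\NC(=S)N1CCCCCC1)c1ccccn1` stands highest of the two measured compounds: in a functional assay on A-375 cells (Homo sapiens) for cytotoxicity, read by MTT assay, with a stated time of 72 h, tested at 30 uM (a lower number here means less inhibition of growth, a higher number more inhibition of growth at the concentration tested), compound 1 gives 90%. Compound 2 `Cc1ccnc(/C(N)=N/NC(=S)N2CCN(c3ccccn3)CC2)c1` gives 79.4% in this assay; it differs from compound 1 in more than one place, and its number lies beyond the scatter below that of compound 1. Compound 3 `Cc1ccnc(/C(N)=N/NC(=S)N2CCCCCC2)c1` arises from compound 1 by methyl in place of hydrogen on an aromatic carbon. Among the compounds with values here, no single step of this kind has been measured here, so the expectation rests on compound 1 alone. The step of a number 5 percentage points lower from compound 1 to compound 3 (within the scatter) is expected to be small, not beyond the scatter, and if anything downward. Compound 3 is estimated at 85%, between 70% and 95%.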

Compound 3, percent growth inhibition at one concentration: 76.5%
The estimate for compound 3 lay 8.5 percentage points above the measured number; the range from low to high includes it.
By their numbers in this assay, from the lowest: compounds 3 and 2 (each within the scatter of the next); then compound 1.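

Methyl in place of hydrogen, on the aromatic carbon opposite the ring nitrogen, gives on its own a number 13.5 percentage points lower from compound 1 to compound 3 (beyond the scatter) in this assay and so shows that this position responds to the addition of a single carbon. The earlier pair differed in more than one place and could not tie a change in the number to this spot. Nothing available here explains the fall. As far as these compounds go, whether an amine, a carboxylic acid or a longer chain at this position would lower the number further, or restore it, remains open.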